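Dimethylphenyl Swap Carried onto a Second Thiazoline Core

The compounds below may be only part of what the source reports. "The series", "measured", "known", "first", "only" and "open" are said of these compounds alone.

Compound 1 `Fc1ccc(C2=NN(C3=NC(c4ccccc4)CS3)C(c3cccc4ccccc34)C2)cc1` gives 23200 nM in a functional assay on HepG2 cells (Homo sapiens) for inhibition, read by CCK-8 assay, with a stated time of 48 h; on this read-out lower numbers stand for stronger inhibition and higher numbers for weaker inhibition. Compound 2 `Cc1ccc(C2=NN(C3=NC(c4ccccc4)CS3)C(c3cccc4ccccc34)C2)cc1C` gives 7250 nM in this assay. The two differ by one change, (3,4-dimethylphenyl in place of 4-fluorophenyl on a carbon with a double bond to nitrogen), and the step is a 3.2-fold lower number from compound 1 to compound 2 (0.51 log units; beyond the scatter). Compound 3 `O=C1CSC(N2N=C(c3ccc(F)cc3)CC2c2ccc3ccccc3c2)=N1` gives 24100 nM in this assay; this value and that of compound 1 lie within the scatter of each other, and the difference between the two cores is not broken down here. Compound 4 `Cc1ccc(C2=NN(C3=NC(=O)CS3)C(c3ccc4ccccc4c3)C2)cc1C` has not yet been measured. It differs from compound 3 by 3,4-dimethylphenyl in place of 4-fluorophenyl on a carbon with a double bond to nitrogen, the same kind of change as before, though the surroundings of the place are not identical: in compound 1 the carbon stands two ring bonds from the ring atom that bears a naphthalen-1-yl group, while in compound 3 it stands two ring bonds from the ring atom that bears a group of 6 heavy atoms. An estimated step of a 2.7-fold lower number from compound 3 to compound 4 (0.43 log units; beyond the scatter) is expected, resting on a 3.2-fold lower number from compound 1 to compound 2 (0.51 log units; beyond the scatter), but tempered since the core of compound 3 is not that of compound 1. Compound 4 is therefore expected at 9000 nM, estimated between 4000 nM and 20000 nM.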

Compound 4, half-maximal inhibitory concentration: 8490 nM
Beside the measured number, compound 4's estimate is 1.1-fold (0.03 log units) above it; the range from low to high includes it.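

In this assay the replacement of 4-fluorophenyl by 3,4-dimethylphenyl goes the same way on the second core, with a 2.8-fold lower number from compound 3 to compound 4 (0.45 log units; beyond the scatter), so in this series the change carries over in both direction and size. The two steps do not differ beyond what repeated measurements would give: the same change on two cores in this assay, a 3.2-fold lower number (0.51 log units; beyond the scatter) from compound 1 to compound 2 and a 2.8-fold lower number (0.45 log units; beyond the scatter) from compound 3 to compound 4, 1.1-fold (0.05 log units) apart, within the scatter of two such steps. This agreement rests on just two matched pairs and one pair of groups, so it shows that the step held on these two cores, but not that it would hold on any other core, and it says nothing about why the change lowers the number.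

The compounds shown leave open whether a single methyl group, as in 4-methylphenyl, would account for the step, or whether both methyl groups are needed. They also leave open how a phenyl ring carrying a carboxylic acid or a dimethylamino group would behave at this place on either core.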